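The source may report more compounds than this note shows. Statements on the series, on what has been measured and on what is new or still open speak of the compounds shown alone.

Measured in a toxicity assay on GES1 cells (Homo sapiens) for inhibition, read by MTT assay, with a stated time of 72 h; a higher number here means a weaker inhibitor, a lower number a stronger inhibitor:
- Compound 1 `Cc1cc(N2CC[C@@H](C)[C@@H](N(C)c3ncnc4[nH]ccc34)C2)n2nc(SCc3ccc(F)c(Cl)c3)nc2n1`: > 100000 nM, a limit of the assay
- Compound 2 `Cc1cc(N2CC[C@@H](C)[C@@H](N(C)c3ncnc4[nH]ccc34)C2)n2nc(SCc3cc(Cl)ccc3Cl)nc2n1`: 87500 nM
- Compound 3 `CCCSc1nc2nc(C)cc(N3CC[C@@H](C)[C@@H](N(C)c4ncnc5[nH]ccc45)C3)n2n1`: 67100 nM

Compound 3 cannot be told apart from compound 2, its nearest neighbour, since the step between them is a 1.3-fold lower number from compound 2 to compound 3 (0.12 log units; within the scatter). The value of compound 1 is only a limit, so it gives no exact comparison.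

Compound 4 `Cc1cc(N2CC[C@@H](C)[C@@H](N(C)c3ncnc4[nH]ccc34)C2)n2nc(SCCCc3ccccc3)nc2n1` extends the sulfur-bound chain of compound 3, turning propyl into 3-phenylpropyl: phenyl in place of hydrogen on a saturated chain carbon, three bonds along the chain from a sulfur. Within the data shown here, two measured steps bear on this, both placing ethyl on a saturated chain carbon bound to a sulfur where an aryl group stood. One is a 1.3-fold lower number from compound 2 to compound 3 (0.12 log units; within the scatter), and the other is an at least 1.4-fold lower number from compound 1 to compound 3 (0.17 log units; that floor lies within the scatter). Neither shows a change beyond the scatter, so adding an aromatic ring to the chain is not expected to move this assay by much. The expected step, leaning slightly towards a higher number, is a 1.2-fold higher number from compound 3 to compound 4 (0.08 log units; within the scatter), which stays within the scatter. For compound 4 the estimated value is 80000 nM, with an expected range of 40000 nM to 100000 nM.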

Compound 4, half-maximal inhibitory concentration: > 100000 nM
Compound 4 was reported as a limit; the forecaster's own chance of this, stated with the estimate: 30%; middle value at least 1.2-fold (0.09 log units) from the limit.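

Moving the aromatic ring out to three bonds along the chain from a sulfur, where compounds 1 and 2 carry theirs on the carbon bound to a sulfur, gave no sign of stronger inhibition in this assay. The step from the plain propyl chain is an at least 1.4-fold higher number from compound 3 to compound 4 (0.17 log units; that floor lies within the scatter), and the step from the 2,5-dichlorophenyl compound is an at least 1.1-fold higher number from compound 2 to compound 4 (0.05 log units; that floor lies within the scatter); both are only floors, and neither goes beyond the scatter. The value of compound 4 is a limit, like that of compound 1, so the step between these two cannot be read: the limit of > 100000 nM in this assay, at which 2 of the 4 values shown sit.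

As far as these compounds go, how far compound 4 lies past that limit stays open. So does whether an amine or a carboxylic acid at the end of the propyl chain, or a longer chain, would give a number clearly apart from these.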